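The compounds below may be only part of what the source reports. "The series", "measured", "known", "first", "only" and "open" are said of these compounds alone.

Compound 1 `O=C(CCCCCNC(=S)NN=C(c1ccccc1)c1ccccc1)NO`: 3640 nM
Compound 2 `O=C(CCCCCNC(=S)N/N=C(\c1ccccc1)c1cccc([N+](=O)[O-])c1)NO`: 940 nM

In a functional assay on K562/A02 cells (Homo sapiens) for antiproliferative activity, read by MTT assay (on this read-out lower numbers stand for stronger inhibition and higher numbers for weaker inhibition), compound 2 holds the lower of the two numbers. Compound 3 `O=C(CCCCCNC(=S)N/N=C(\c1ccccc1)c1ccc([N+](=O)[O-])cc1)NO` has 4-nitrophenyl in place of 3-nitrophenyl on a carbon with a double bond to nitrogen. Going by the values given here, one measured step bears on this change: a 3.9-fold lower number from compound 1 to compound 2 (0.59 log units; beyond the scatter), where nitro replaced hydrogen on an aromatic carbon. That step shows the gain on adding the nitro, not the result of moving it, so no step beyond the scatter is expected in this assay. The estimated step is a 1.1-fold higher number from compound 2 to compound 3 (0.03 log units; within the scatter). For compound 3 the expected value is 1000 nM, with an estimated range of 450 nM to 2300 nM.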

Compound 3, half-maximal inhibitory concentration: 4530 nM
For compound 3 the middle estimate is 4.5-fold (0.66 log units) below the measured one; measured number above the stated range.
By their numbers in this assay, from the lowest: compound 2; then compounds 1 and 3 (each within the scatter of the next).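

In this assay, the nitro group's effect depends on where it sits, since 4-nitrophenyl in place of 3-nitrophenyl gives a clear loss (a 4.8-fold higher number from compound 2 to compound 3 (0.68 log units; beyond the scatter)). The gain seen with 3-nitrophenyl does not carry over to 4-nitrophenyl, as nitro in place of hydrogen here leaves the number within the scatter (a 1.2-fold higher number from compound 1 to compound 3 (0.09 log units; within the scatter)). Nothing measured here explains the difference between these two groups. From the compounds shown here alone, it remains open whether an amine or a carboxylic acid in place of the nitro would show the same dependence on position, and whether 3-nitrophenyl would keep its gain with a longer chain.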